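A few compounds are considered here, and "the series" means these few. Any claim that something is new, unique, unknown or untested is made for them only; others in the source may bear on it.

Measured in an assay on CHO cells for antagonist activity at transient receptor potential cation channel subfamily V member 1 (Homo sapiens), read by FLIPR and calcium flux; a lower number here means a stronger inhibitor, a higher number a weaker inhibitor:
compound 1 `CC(C(=O)NCc1ccc(C(F)(F)F)nc1Cl)c1ccc(NS(C)(=O)=O)c(F)c1` gives 0.2 nM
compound 2 `CCCc1nc(C(F)(F)F)ccc1CNC(=O)C(C)c1ccc(NS(C)(=O)=O)c(F)c1` gives 22.7 nM
compound 3 `CC(C(=O)NCc1ccc(C(F)(F)F)nc1C1CCC(F)(F)CC1)c1ccc(NS(C)(=O)=O)c(F)c1` gives 1.5 nM

Compound 2 has the highest number of the three: a 110-fold higher number from compound 1 to compound 2 (2.05 log units; beyond the scatter) and a 15-fold lower number from compound 2 to compound 3 (1.18 log units; beyond the scatter) are both beyond the scatter, so compound 2 is the weakest inhibitor of this set. Compound 4 `CC(C(=O)NCc1ccc(C(F)(F)F)nc1C1=CCCCC1)c1ccc(NS(C)(=O)=O)c(F)c1` differs from compound 2 by cyclohex-1-en-1-yl in place of propyl on an aromatic carbon. Within the data shown here, the closest precedent is a 15-fold lower number from compound 2 to compound 3 (1.18 log units; beyond the scatter), where a six-membered ring also replaced propyl on the same aromatic carbon; a 7.5-fold higher number from compound 1 to compound 3 (0.88 log units; beyond the scatter) shows that ring still falls short of chloro. A large fall in this assay is therefore expected for compound 4, estimated at an 11-fold lower number from compound 2 to compound 4 (1.05 log units; beyond the scatter). The estimate for compound 4 is 2 nM, range 0.5 nM to 8 nM; with a single ring precedent the range is kept wide.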

Compound 4, inhibition constant: 0.7 nM
The estimate for compound 4 lay 2.9-fold (0.46 log units) above the measured number; the measured number falls inside the stated range.
By their numbers in this assay, from the lowest: compound 1; then compound 4; then compound 3; then compound 2.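

In this assay a second six-membered ring on this aromatic carbon also improves on propyl, with a 32-fold lower number from compound 2 to compound 4 (1.51 log units; beyond the scatter) showing that the gain is not unique to 4,4-difluorocyclohexyl. Cyclohex-1-en-1-yl in place of that group gives a 2.1-fold lower number from compound 3 to compound 4 (0.33 log units; beyond the scatter) and yet in place of chloro gives a 3.5-fold higher number from compound 1 to compound 4 (0.54 log units; beyond the scatter) so neither ring group shown matches chloro. No measurement shown accounts for these differences.

Open, going by these compounds, is whether plain cyclohexyl would sit closer to compound 3 or compound 4, since those two differ in both the double bond and the fluorines. Also open, on these data alone, is whether a smaller ring such as cyclopropyl would close the remaining distance to compound 1.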